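Dichlorophenyl for Aminophenyl on the Carbonyl: an Expected Reading

This account rests on a few compounds, and the source may have more. Where it says the series, first, only, none or still open, it means among the compounds named here.

Compound 1, `COc1cc(-c2cc(/C=C/C(=O)c3ccc(N)cc3)[nH]n2)cc(OC)c1OC`: 98%
Compound 2, `COc1ccc(-c2cc(/C=C/C(=O)c3ccc(OC)c(OC)c3)[nH]n2)cc1`: 89%

In a functional assay on Malme-3M cells (Homo sapiens) for cytotoxicity, read by sulforhodamine B assay, with a stated time of 48 h, tested at 0.01 uM (a higher number here means a weaker effect of the compound at the concentration tested, a lower number a stronger effect), compound 1 gives 98%, and compound 2 gives 89%; the two numbers lie within the scatter of each other, so neither can be set apart from the other. Going by the values given here, no step between two measured compounds that differ in a single place is available.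

Compound 3, `COc1cc(-c2cc(/C=C/C(=O)c3ccc(Cl)c(Cl)c3)[nH]n2)cc(OC)c1OC`, differs from compound 1 in one place: 3,4-dichlorophenyl in place of 4-aminophenyl on a carbonyl carbon. With both measured compounds reading high, the step from compound 1 to compound 3 is expected to stay within the scatter, estimated as a number 4 percentage points lower from compound 1 to compound 3 (within the scatter). Compound 3 is therefore expected to give 94%, with a range from 80% to 106%.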

Compound 3, a percentage reported as activity, at one concentration (the size of the read-out at that concentration, not a potency): 94%
For compound 3 middle estimate and measured number coincide at the digits printed; the range from low to high includes it.
By their numbers in this assay, from the lowest: compounds 2, 3 and 1 (each within the scatter of the next).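

In this assay, going by these compounds alone, the first comparison at this position gives a number 4 percentage points lower from compound 1 to compound 3 (within the scatter), so 3,4-dichlorophenyl and 4-aminophenyl on the carbonyl carbon cannot be told apart. The swap removes the hydrogen-bond donor and acceptor counted on the leaving group, yet the read-out at this single concentration does not separate the two compounds. Nothing measured here bears on why they read alike.

As far as these compounds go, it remains open whether a group bearing a carboxylic acid or a morpholine at this place would give a clearly lower number in this assay.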